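The source may report more compounds than this note shows. Statements on the series, on what has been measured and on what is new or still open speak of the compounds shown alone.

Three compounds share one core and differ only in the group on a saturated chain carbon bound to a sulfur. In a functional assay on HGC-27 cells (Homo sapiens) for inhibition, read by MTT assay, with a stated time of 72 h (a lower number here means a stronger inhibitor, a higher number a weaker inhibitor), compound 1 `CCCSc1nc2nc(C)cc(N3CC[C@@H](C)[C@@H](N(C)c4ncnc5[nH]ccc45)C3)n2n1` gives 20900 nM, compound 2 `Cc1cc(N2CC[C@@H](C)[C@@H](N(C)c3ncnc4[nH]ccc34)C2)n2nc(SCc3ccc(C(F)(F)F)cc3)nc2n1` gives 9540 nM, and compound 3 `C=CCSc1nc2nc(C)cc(N3CC[C@@H](C)[C@@H](N(C)c4ncnc5[nH]ccc45)C3)n2n1` gives 35200 nM, the highest of the three numbers; its gap to compound 1 lies within the scatter, while a 3.7-fold higher number from compound 2 to compound 3 (0.57 log units; beyond the scatter) goes beyond it. Compound 4 `Cc1cc(N2CC[C@@H](C)[C@@H](N(C)c3ncnc4[nH]ccc34)C2)n2nc(SCc3nc4ccccc4[nH]3)nc2n1` carries 1H-benzimidazol-2-yl in place of vinyl on a saturated chain carbon bound to a sulfur. The step that bears on this is a 3.7-fold higher number from compound 2 to compound 3 (0.57 log units; beyond the scatter), where an aromatic ring in place of vinyl went with a lower number, and a 2.2-fold lower number from compound 1 to compound 2 (0.34 log units; beyond the scatter) points the same way. With another aromatic ring entering, compound 4 is expected to show a 2.9-fold lower number from compound 3 to compound 4 (0.47 log units; beyond the scatter). The estimate for compound 4 is 12000 nM, within 4000 nM to 40000 nM.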

Compound 4, half-maximal inhibitory concentration: > 100000 nM
Compound 4: only a limit was reported; the forecaster's own chance of this, stated with the estimate: 5%; at least 8.3-fold (0.92 log units) between middle value and limit.
By their numbers in this assay, from the lowest: compound 2; then compounds 1 and 3 (each within the scatter of the next). At a limit, above all of these: compound 4.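

Compound 4 is reported only as a limit: the limit of > 100000 nM in this assay, at which 1 of the 4 values shown sits. An aromatic ring on this saturated chain carbon bound to a sulfur therefore does not by itself go with a lower number, since 1H-benzimidazol-2-yl in place of 4-(trifluoromethyl)phenyl gives an at least 10-fold higher number from compound 2 to compound 4 (1.02 log units; beyond the scatter). Compound 4 also falls behind the two smaller groups, with an at least 4.7-fold higher number from compound 1 to compound 4 (0.67 log units; beyond the scatter) and an at least 2.8-fold higher number from compound 3 to compound 4 (0.45 log units; beyond the scatter).

The compounds shown cannot separate the effect of the fused ring pair from that of its nitrogens and hydrogen-bond donor. An unsubstituted phenyl or a naphthyl group at this place would help to tell these apart.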